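The source may report more compounds than this note shows. Statements on the series, on what has been measured and on what is new or still open speak of the compounds shown alone.

Measured so far:
compound 1 `O=C(CSc1nc(Nc2ccccc2)c2ccccc2n1)Nc1cccc(F)c1`: > 50000 nM
compound 2 `O=C(CSc1nc(Nc2ccccc2)c2ccccc2n1)Nc1cccc(Cl)c1`: 16500 nM
compound 3 `C=CC(=O)Nc1cccc(NC(=O)CSc2nc(Nc3cccc(F)c3)c3ccccc3n2)c1`: 8160 nM

In a functional assay on MDA-MB-231 cells (Homo sapiens) for inhibition, read by MTT assay, with a stated time of 72 h (a lower number here means a stronger inhibitor, a higher number a weaker inhibitor), compound 1 reaches only the limit of the assay, > 50000 nM. Compound 2 carries chloro in place of fluoro on an aromatic carbon and gives 16500 nM in this assay; the step of an at least 3.0-fold lower number from compound 1 to compound 2 (0.48 log units; beyond the scatter) is known only as a floor because of the limit of > 50000 nM in this assay, at which 1 of the 3 values shown sits. Compound 3 gives 8160 nM in this assay and stands lowest of the two numbers; the difference between its core and that of compound 1 is not broken down here.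

Compound 4 `C=CC(=O)Nc1cccc(NC(=O)CSc2nc(Nc3cccc(Cl)c3)c3ccccc3n2)c1` is not yet measured. It differs from compound 3 by chloro in place of fluoro on an aromatic carbon, the same change as between compound 1 and compound 2. For compound 4 the expected step is a 3.0-fold lower number from compound 3 to compound 4 (0.48 log units; beyond the scatter), resting on an at least 3.0-fold lower number from compound 1 to compound 2 (0.48 log units; beyond the scatter), which itself is only a floor. Compound 4 is therefore estimated at 2700 nM, expected between 900 nM and 8000 nM.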

Compound 4, half-maximal inhibitory concentration: 16300 nM
The estimate for compound 4 lay 6.0-fold (0.78 log units) below the measured number, outside the stated range (above it).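

On the core of compound 3, chloro in place of fluoro on an aromatic carbon gives a 2.0-fold higher number from compound 3 to compound 4 (0.30 log units; within the scatter) in this assay, so the step seen on the core of compound 1 does not carry over to this core: the same change on two cores in this assay, an at least 3.0-fold lower number (0.48 log units; beyond the scatter) from compound 1 to compound 2 and a 2.0-fold higher number (0.30 log units; within the scatter) from compound 3 to compound 4, at least 6.0-fold (0.78 log units) apart, beyond the scatter of two such steps.

As far as these compounds go, compound 1 stands at a limit of the assay, so the earlier step is only a floor and the full gap between the two steps stays unknown: the limit of > 50000 nM in this assay, at which 1 of the 4 values shown sits.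

With one pair on each core, these data give no general rule for this change across the series, and they do not show what separates the two cores.

Open, from the compounds shown here alone, is whether a methyl, methoxy or trifluoromethyl group in place of the halogen would follow the step on either core. Also open, going by these compounds, is how bromo at the same place would read on each core.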